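This account rests on a few compounds, and the source may have more. Where it says the series, first, only, none or still open, it means among the compounds named here.

Of the compounds shown here, three from this series have been tested in a functional assay on HeLa cells (Homo sapiens) for inhibition, read by sulforhodamine B assay, with a stated time of 48 h; a higher number here means a weaker inhibitor of growth, a lower number a stronger inhibitor of growth. Compound 1, `COC(=O)[C@@]1(C)CCC=C2[C@@H]1CC[C@@H](C)[C@]2(C)Cc1c[nH]c2ccc(Br)cc12`, gives 10000 nM. Compound 2, `COC(=O)[C@@]1(C)CCC=C2[C@@H]1CC[C@@H](C)[C@]2(C)Cc1c(C)[nH]c2ccc(C)cc12`, gives 17000 nM. Compound 3, `COC(=O)[C@@]1(C)CC[C@@H]2C3=C1CC[C@@H](C)[C@]3(C)C[C@@H]1c3cc(C)ccc3N[C@H]21`, gives 18000 nM. All three numbers lie in the same region and every gap among them falls within the usual scatter of repeated measurements, so compound 3 cannot be set apart from compound 1 or compound 2 on these results; it simply belongs to a group of weak growth inhibitors.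

Compound 4, `COC(=O)[C@@]1(C)CC[C@@H]2C3=C1CC[C@@H](C)[C@]3(C)C[C@@H]1c3cc(F)ccc3N[C@H]21`, is the next member and has not yet been measured in this assay. It is built on the same core as compound 3 and differs from it in only one place: fluoro in place of methyl on an aromatic carbon. Among the compounds with values here, no pair of measured compounds shows what such a swap does, so there is no measured step to lean on. Given that the three measured compounds sit so close together, the step from compound 3 to compound 4 is expected to be small and in no particular direction, meaning a 1.1-fold lower number from compound 3 to compound 4 (0.05 log units; within the scatter) as a best guess that stays inside the scatter. Compound 4 is therefore estimated to give 16000 nM, with a plausible range from 6000 nM to 45000 nM.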

Compound 4, concentration for 50% growth inhibition: 20000 nM
The estimate for compound 4 lay 1.3-fold (0.10 log units) below the measured number; the measured number falls inside the stated range.
By their numbers in this assay, from the lowest: compounds 1, 2, 3 and 4 (each within the scatter of the next).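

In this assay, fluoro in place of methyl on this aromatic carbon gives a 1.1-fold higher number from compound 3 to compound 4 (0.05 log units; within the scatter), so the two compounds cannot be told apart. The earlier compounds shown here included no pair differing in one place, which left this position without a direct comparison; this pair provides the first, showing that at this carbon, meta to one fused ring and para to another, the swap between these two groups produces no readable difference in growth inhibition. No supporting measurement is available to explain this result or to describe what either group contributes at this carbon.

One swap between two small groups cannot show whether this position tolerates substitution generally or whether these two groups merely happen to give similar readings. An amine, a carboxylic acid or a longer chain such as butyl at the same carbon would test that more broadly, and the compounds shown leave open whether any group here could give a number clearly different from those of compound 3 and compound 4.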